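This account rests on a few compounds, and the source may have more. Where it says the series, first, only, none or still open, it means among the compounds named here.

Compound 2 `Cc1ccccc1Nc1nc(SCc2ccc(C(F)(F)F)cc2)nc2ccccc12` gives 24400 nM in a functional assay on MGC-803 cells (Homo sapiens) for cytotoxicity, read by MTT assay, with a stated time of 72 h (on this read-out higher numbers stand for weaker inhibition and lower numbers for stronger inhibition), the higher of the two numbers measured here. Compound 3 `O=[N+]([O-])c1ccc(Nc2nc(SCc3ccc(C(F)(F)F)cc3)nc3ccccc23)cc1` gives 8170 nM in this assay. For compound 1 `CCCCCCCCCCCCCCNc1nc(SCc2ccc(C(F)(F)F)cc2)nc2ccccc12` this assay reports only a limit, > 50000 nM. For the measured compounds named here, the one step measured between compounds that differ in a single place is a 3.0-fold lower number from compound 2 to compound 3 (0.48 log units; beyond the scatter), a change on the same nitrogen that compound 4 alters.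

Compound 4 `COc1cc(Nc2nc(SCc3ccc(C(F)(F)F)cc3)nc3ccccc23)cc(OC)c1` differs from compound 2 as follows: 3,5-dimethoxyphenyl in place of 2-methylphenyl on a nitrogen on an aromatic ring. Going by the values given here, the only step that bears on this position is the modest lowering from compound 2 to compound 3; the group entering compound 4 is not a 4-nitrophenyl, so that step is a loose guide at best. A small lowering or no change beyond the scatter is expected, and the estimated step is a 1.6-fold lower number from compound 2 to compound 4 (0.21 log units; within the scatter). Compound 4 is therefore expected to give about 15000 nM in this assay, with a likely range from 5000 nM to 45000 nM.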

Compound 4, half-maximal inhibitory concentration: 8580 nM
Compound 4: the middle estimate sits 1.7-fold (0.24 log units) above what was measured, within the range that was stated.
By their numbers in this assay, from the lowest: compounds 3 and 4 (each within the scatter of the next); then compound 2. At a limit, above all of these: compound 1.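

Compound 4 shows that the 2-methylphenyl on this nitrogen can give way to a second, quite different aromatic group with a modest shift in this assay, namely a 2.8-fold lower number from compound 2 to compound 4 (0.45 log units; beyond the scatter), close in size to the step already seen with the 4-nitrophenyl. The 3,5-dimethoxyphenyl and the 4-nitrophenyl cannot be told apart here, since the step between them, a 1.1-fold higher number from compound 3 to compound 4 (0.02 log units; within the scatter), stays inside the usual scatter, so this position tolerates two quite different sets of ring substituents with the same outcome. Nothing shown explains why these two groups match each other or why both part from the 2-methylphenyl.

The compounds shown leave open where an unsubstituted phenyl on this nitrogen would fall, and whether an amine or a carboxylic acid on that ring would lower the number further. They also leave open what a nitrile in place of the trifluoromethyl would do.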